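Methoxy for Isobutyl on an Amide Nitrogen

The source may hold more compounds than are shown below. What is called first, only, known or untested is meant among the compounds shown, and "the series" means these compounds.

Of the compounds shown here, two sharing a core have been measured in an assay on HEK293 cells for agonist activity at transient receptor potential cation channel subfamily M member 8 (Homo sapiens), read by fluorescence and calcium flux, with a stated time of 15 min; on this read-out higher numbers stand for an effect only at larger amounts of compound and lower numbers for an effect already at smaller amounts. Compound 1 `CCN(Cc1ccco1)C(=O)COc1ccc(C)cc1` carries an ethyl group and a furanylmethyl group on its amide nitrogen, and in this assay compound 1 gives 489 nM. Compound 2 `Cc1ccc(OCC(=O)N(Cc2cccs2)CC(C)C)cc1` carries an isobutyl group and a thienylmethyl group on the same nitrogen, and in this assay compound 2 gives 900 nM. These two numbers are the only ones in hand, and the gap between them lies within the usual scatter of repeated measurements, so nothing separates compound 1 from compound 2 on this read-out.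

Compound 3 `CON(Cc1cccs1)C(=O)COc1ccc(C)cc1` is compound 2 with one change: methoxy in place of isobutyl on an amide-type nitrogen. Within the data shown here, no measured pair in this set shows the effect of such an exchange, so any expectation rests on the structural change alone. The author expects compound 3 to give 2500 nM in this assay, within a range from 700 nM to 9000 nM, which would mean an expected step of a 2.8-fold higher number from compound 2 to compound 3 (0.44 log units; beyond the scatter), most likely a rise beyond the scatter rather than a fall.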

Compound 3, half-maximal effective concentration: 10 nM
The estimate for compound 3 lay 250-fold (2.40 log units) above the measured number; measured number below the stated range.
By their numbers in this assay, from the lowest: compound 3; then compounds 1 and 2 (each within the scatter of the next).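

Replacing isobutyl with methoxy on an amide-type nitrogen whose other neighbours are the carbonyl carbon and a saturated chain carbon gives a 90-fold lower number from compound 2 to compound 3 (1.95 log units; beyond the scatter) in this assay. Compound 1 and compound 2 differ in more than one place and lie within the scatter of each other, so they gave no sign of what this single exchange now shows: the read-out can respond very strongly to the group at this position. Methoxy brings an oxygen and a hydrogen-bond acceptor that isobutyl lacks, but no measurement offered here explains the step or ties it to either feature.

The compounds shown leave open whether the oxygen or the shorter group matters more, a question that a methyl, an ethoxy or a hydroxyl group on the same nitrogen could help to separate. They also leave open whether methoxy would bring a comparable step with the furanylmethyl group of compound 1 in place of the thienylmethyl group of compound 3.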